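Changing the Side Chain on a Weakly Inhibiting Compound

The source may hold more compounds than are shown below. What is called first, only, known or untested is meant among the compounds shown, and "the series" means these compounds.

Among the measured compounds shown here, compound 2 `CC(O)n1cnc2c(N)nc(I)nc21` is the only compound here with a measured number in a functional assay on L1210 cells (Mus musculus) for inhibition; a lower number here means a stronger inhibitor, a higher number a weaker inhibitor: compound 2 gives 490000 nM. Compound 1 `CC(O)n1cnc2c(Cl)nc(I)nc21` reached only a limit in this assay, namely > 500000 nM; that is the limit of > 500000 nM in this assay, at which 1 of the 2 values shown sits. For the measured compounds named here, the step of an at least 1.0-fold lower number from compound 1 to compound 2 (0.00 log units; that floor lies within the scatter) is the sole measured comparison, and it concerns an aromatic carbon, not the ring nitrogen that changes next. Compound 3 `Nc1nc(I)nc2c1ncn2OCCO` carries 2-hydroxyethoxy in place of 1-hydroxyethyl on an aromatic nitrogen. Going by the values given here, no measured step bears on this position, so no shift beyond the scatter is expected. Compound 3 is estimated in this assay at 490000 nM, between 150000 nM and 1500000 nM. The expected step is no change at the digits printed from compound 2 to compound 3 (within the scatter).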

Compound 3, half-maximal inhibitory concentration: > 500000 nM
Compound 3 gave a limit, no number; the forecaster's own chance of this, stated with the estimate: 55%; middle value at least 1.0-fold (0.00 log units) from the limit.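

Among the compounds shown here, at the aromatic nitrogen, 2-hydroxyethoxy in place of 1-hydroxyethyl gives an at least 1.0-fold higher number from compound 2 to compound 3 (0.00 log units; that floor lies within the scatter), the first measured step at this position, and it reveals no stronger inhibition. Compound 3 reached only a limit in this assay, so the true size of this step cannot be read. The compounds shown now gather at that limit: the limit of > 500000 nM in this assay, at which 2 of the 3 values shown sit.

Going by these compounds, it remains open whether a carboxylic acid or an amine at the end of a longer chain on this ring nitrogen would give a measurable number well clear of that limit.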